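Trimming a Ring to a Methyl on the Shared Core

The source may hold more compounds than are shown below. What is called first, only, known or untested is meant among the compounds shown, and "the series" means these compounds.

Compound 1, `CNc1nc(-n2cc(CC3CCCCC3)nn2)nc2c1ncn2[C@@H]1O[C@H](CO)[C@@H](O)[C@H]1O`, is measured in an assay on CHO cells for displacement of a labelled ligand from adenosine receptor A3 (Homo sapiens) (a higher number here means a weaker inhibitor, a lower number a stronger inhibitor), and gives 21.3 nM, the lowest of the two numbers recorded there. Compound 2, `CNc1nc(-c2cn(Cc3cccc(Cl)c3)nn2)nc2c1ncn2[C@@H]1O[C@H](CO)[C@@H](O)[C@H]1O`, gives 81.1 nM in this assay, a gap to compound 1 that is beyond the usual scatter. Compound 3, `CCc1cn(-c2nc(NC)c3ncn([C@@H]4O[C@H](CO)[C@@H](O)[C@H]4O)c3n2)nn1`, is not yet measured; it differs from compound 1 by methyl in place of cyclohexyl on a saturated chain carbon bound to an aromatic carbon. Among the measured compounds shown here, with no measured step of this kind to lean on, the loss of the six-membered ring is expected to raise the number modestly, as the step of a 4.0-fold higher number from compound 1 to compound 3 (0.60 log units; beyond the scatter) expresses. Compound 3 is therefore estimated at 85 nM, within a range of 25 nM to 300 nM.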

Compound 3, inhibition constant: 13.8 nM
For compound 3 the middle estimate is 6.2-fold (0.79 log units) above the measured one, outside the stated range (below it).
By their numbers in this assay, from the lowest: compounds 3 and 1 (each within the scatter of the next); then compound 2.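

In this assay, the cyclohexyl ring turns out not to be needed at this position: methyl in its place, on a saturated chain carbon bound to an aromatic carbon, gives a 1.5-fold lower number from compound 1 to compound 3 (0.19 log units; within the scatter). Cutting cyclohexylmethyl back to ethyl therefore leaves the number unchanged within the scatter. Nothing available accounts for this outcome.

The compounds shown leave open how this position responds to a longer chain such as propyl. They also leave open what an amine or a carboxylic acid at the end of the chain would do.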